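Anilide series: chloro to methoxy at the amide aryl

A few compounds are considered here, and "the series" means these few. Any claim that something is new, unique, unknown or untested is made for them only; others in the source may bear on it.

Three members of the series have a number in an ADME assay on HepG2 2.2.15 cells (Homo sapiens) for cytotoxicity, read by MTT assay, with stated times of 48 h and 9 days; on this read-out lower numbers stand for higher toxicity in this test and higher numbers for lower toxicity in this test. Compound 1 `COc1ccc2c(=O)c(/C=C/C(=O)Nc3ccc(Cl)cc3)coc2c1` gives 272000 nM, the lowest of the three, though its gap to compound 2 `Cc1ccccc1NC(=O)/C=C/c1coc2cc(O)ccc2c1=O` with 374000 nM and to compound 3 `Cc1ccc(CNC(=O)/C=C/c2coc3cc(O)ccc3c2=O)cc1` with 501000 nM stays within the scatter. Among the measured compounds shown here, the only step between two measured compounds, a 1.3-fold higher number from compound 2 to compound 3 (0.13 log units; within the scatter), concerns a change on the amide nitrogen and is itself within the scatter.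

Compound 4 `COc1ccc(NC(=O)/C=C/c2coc3cc(OC)ccc3c2=O)cc1` is not yet measured. It differs from compound 1 as follows: methoxy in place of chloro on an aromatic carbon. For the measured compounds named here, no measured pair carries this chloro-to-methoxy exchange, so nothing speaks directly to it; what the three numbers show is that changes at the amide side so far left this assay unmoved beyond its scatter. The expectation for compound 4 is therefore a step of a 1.1-fold higher number from compound 1 to compound 4 (0.04 log units; within the scatter), that is, none beyond the scatter. The estimated value for compound 4 is 300000 nM, with a range from 140000 nM to 650000 nM.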

Compound 4, half-maximal cytotoxic concentration: 718000 nM
Compound 4: middle estimate off by 2.4-fold (0.38 log units), on the low side, and the stated range ends below it.
By their numbers in this assay, from the lowest: compounds 1, 2, 3 and 4 (each within the scatter of the next, the first and the last beyond it).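

In this assay, the exchange of 4-chlorophenyl for 4-methoxyphenyl gives a 2.6-fold higher number from compound 1 to compound 4 (0.42 log units; beyond the scatter) and so moves the read-out modestly toward lower toxicity in this test. Among the compounds shown here, this is the first step beyond the scatter, whereas the earlier step, a 1.3-fold higher number from compound 2 to compound 3 (0.13 log units; within the scatter), stayed within it, so the group on this aromatic carbon, para to a large group, can shift the number even though the shift is small. No measurement at hand bears on the reason for this step.

As far as these compounds go, a single pair defines this position, so whether a dimethylamino group or a carboxylic acid in the same place would extend or reverse the step remains open. Also open, from the compounds shown here alone, is whether the exchange gives a similar step on the core of compound 2, which carries hydroxy where compound 1 carries methoxy.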